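Hydroxy on the Pyrimidine Tail of Compound 1

The source may report more compounds than this note shows. Statements on the series, on what has been measured and on what is new or still open speak of the compounds shown alone.

Compound 1 `CS(=O)(=O)c1ccc2c(c1)CCN2c1ncnc2c(C3CCN(c4ncccn4)CC3)coc12`: 512 nM
Compound 2 `CN(c1ccc(S(C)(=O)=O)cc1F)c1ncnc2c(C3CCN(C(=O)OC(C)(C)C)CC3)coc12`: > 1000 nM (a limit of the assay, not a number)
Compound 3 `CC(C)(C)OC(=O)N1CCC(c2noc3c(Nc4ccc(S(C)(=O)=O)cc4F)ncnc23)CC1`: 353 nM

In a functional assay on cells for agonist activity at Glucose-dependent insulinotropic receptor (Homo sapiens), read by a luciferase reporter, with a stated time of 4 h (a lower number here means that less compound is needed, a higher number that more compound is needed for the effect), compound 1 gives 512 nM, the higher of the two numbers available, while compound 3 gives 353 nM, which lies within the scatter of that. Compound 2 sits at the limit of > 1000 nM in this assay, at which 1 of the 3 values shown sits.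

Compound 4 `CS(=O)(=O)c1ccc2c(c1)CCN2c1ncnc2c(C3CCN(c4ncc(O)cn4)CC3)coc12` has not yet been measured. It differs from compound 1 by hydroxy in place of hydrogen on an aromatic carbon. Among the measured compounds shown here, no pair of measured compounds isolates such a change, so the step of a 1.2-fold lower number from compound 1 to compound 4 (0.09 log units; within the scatter) is expected to be small, in either direction, and not clearly beyond the scatter. Compound 4 is therefore estimated at about 420 nM, with a range from 150 nM to 1200 nM.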

Compound 4, half-maximal effective concentration: 391 nM
Compound 4: middle estimate off by 1.1-fold (0.03 log units), on the high side, within the range that was stated.
By their numbers in this assay, from the lowest: compounds 3, 4 and 1 (each within the scatter of the next). At a limit, above all of these: compound 2.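

In this assay, the change from pyrimidin-2-yl to 5-hydroxypyrimidin-2-yl gives a 1.3-fold lower number from compound 1 to compound 4 (0.12 log units; within the scatter). This is the first step shown at this position, and it indicates that a hydroxy group on this aromatic carbon, para to a large group, leaves the number of compound 1 within the scatter. Nothing measured here gives a cause for this step. The compounds shown leave open whether an amine or a carboxylic acid on the same carbon would also stay within the scatter. They also leave open whether hydroxy would do so on another core.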